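The compounds below may be only part of what the source reports. "The series", "measured", "known", "first", "only" and "open" are said of these compounds alone.

Measured so far in an ADME assay on the whole organism (serum, Rattus norvegicus) for protein binding; a lower number here means a smaller unbound share, a higher number a larger unbound share of the compound:
compound 1, `O=C(C1=C(O)C(=O)N(c2ccc(-c3ccon3)cc2)C1C1CCCCC1)c1ccc(CO)cc1`, gives 0.004.
compound 2, `O=C(O)c1ccc(C(=O)C2=C(O)C(=O)N(c3ccc(-c4ccon4)cc3)C2C2CCCCC2)cc1`, gives 0.008.

Two numbers only. Among the measured compounds shown here, compound 2 stands beside compound 1 in this assay: the single step between them, a 2.0-fold higher number from compound 1 to compound 2 (0.30 log units; within the scatter), stays within the scatter, so neither number can be set apart from the other.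

Compound 3, `CNC(=O)c1ccc(C(=O)C2=C(O)C(=O)N(c3ccc(-c4ccon4)cc3)C2C2CCCCC2)cc1`, is not yet measured. It differs from compound 2 in one place: methylamino in place of hydroxy on a carbonyl carbon. For the measured compounds named here, no measured step covers this change. Going by the values given here, the only step in hand, a 2.0-fold higher number from compound 1 to compound 2 (0.30 log units; within the scatter), concerns hydroxymethyl against carboxy on an aromatic carbon and did not move the number beyond the scatter; the methylcarbamoyl end of the present change is untested, so that step gives no direction. With nothing that bears on it, the expectation for compound 3 is a number close to compound 2, and the step of a 1.3-fold lower number from compound 2 to compound 3 (0.12 log units; within the scatter) is expected to stay within the scatter. The estimate for compound 3 in this assay is 0.006, with a range from 0.0025 to 0.015.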

Compound 3, unbound fraction: 0.007
Beside the measured number, compound 3's estimate is 1.2-fold (0.07 log units) below it, within the range that was stated.
By their numbers in this assay, from the lowest: compounds 1, 3 and 2 (each within the scatter of the next).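

Methylamino in place of hydroxy on a carbonyl carbon, which reads as 4-carboxyphenyl to 4-(methylcarbamoyl)phenyl, gives a 1.1-fold lower number from compound 2 to compound 3 (0.06 log units; within the scatter) in this assay, so this exchange leaves the read-out within the scatter. Against the hydroxymethyl end of the series, methylcarbamoyl gives a 1.8-fold higher number from compound 1 to compound 3 (0.24 log units; within the scatter) and is also within the scatter, so hydroxymethyl, carboxy and methylcarbamoyl at this place cannot be set apart in the unbound fraction, a statement limited to compound 1, compound 2 and compound 3. No supporting measurement bears on why these three groups cannot be told apart in this read-out.

Still open, from the compounds shown here alone, is whether any group at this place can move the number beyond the scatter, for example an aminomethyl group in place of hydroxymethyl on an aromatic carbon, or dimethylamino or a longer chain such as butylamino in place of methylamino on the carbonyl carbon. Also open, going by these compounds, is whether the unbound fraction answers to a change elsewhere on the shared core, since all three compounds differ only at this one place.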